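The source may hold more compounds than are shown below. What is called first, only, known or untested is meant among the compounds shown, and "the series" means these compounds.

Of the compounds shown here, two sharing one core have so far been measured in a functional assay on HEK293 cells for agonist activity at G-protein coupled receptor 52 (Homo sapiens), read by cAMP accumulation, with a stated time of 15 min; on this read-out higher numbers stand for larger maximal responses and lower numbers for smaller maximal responses. Compound 1, `O=C(NCCO)c1cccc2c1CCN2c1nccc(Cc2cc(F)cc(C(F)(F)F)c2)n1`, gives in this assay 138%. Compound 2, `O=C(NCCO)c1cccc2c1CCN2c1cc(Cc2ccc(C(F)(F)F)cc2)ncn1`, gives in this assay 136%. Among the measured compounds shown here, with only two numbers on the table, compound 2 has a single neighbour, compound 1, and the gap between the two values lies within the usual scatter of repeated measurements; no ordering between them can be read from these numbers.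

The account now turns to compound 3, `O=C(NCCO)c1cccc2c1CCN2c1cc(Cc2cccc(OC(F)(F)F)c2)ncn1`, which has not yet been measured in this assay. Relative to compound 2 the change is 3-(trifluoromethoxy)phenyl in place of 4-(trifluoromethyl)phenyl on a saturated chain carbon bound to an aromatic carbon. For the measured compounds named here, no measured pair differs in exactly this way, so there is no measured step to lean on; all the numbers show is that compound 1 and compound 2, which differ in several places, sit within the scatter of each other.

On that basis the expected step is a number 4 percentage points lower from compound 2 to compound 3 (within the scatter), that is, nothing beyond the scatter in either direction. Compound 3 is therefore estimated to give 132%, with a range from 105% to 150%.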

Compound 3, largest response reached (Emax), in percent of the reference or control that the assay uses: 113%
Compound 3: the middle estimate sits 19 percentage points above what was measured; low and high end bracket the measured number.
By their numbers in this assay, from the lowest: compound 3; then compounds 2 and 1 (each within the scatter of the next).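

In this assay, the aryl group on a saturated chain carbon bound to an aromatic carbon proves able to change the maximal response: putting 3-(trifluoromethoxy)phenyl in place of 4-(trifluoromethyl)phenyl gives a number 23 percentage points lower from compound 2 to compound 3 (beyond the scatter). Among the compounds shown here, compound 1 and compound 2 differ in several places, so they could not show what any single change does, and this is the first step that isolates one change and lies beyond the scatter. No measurement at hand bears on why the response falls with this exchange.

The exchange alters two things at once, the group on the ring and where it sits, so the compounds shown cannot say which of the two carries the step; a 3-(trifluoromethyl)phenyl or a 4-(trifluoromethoxy)phenyl group at this place would separate them. From the compounds shown here alone, it also stays open whether other groups here, such as a plain phenyl or a 3-chlorophenyl, would match compound 2 or compound 3, and whether the same exchange would give a similar step on the core of compound 1.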